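Thiadiazole sulfides on a trifluoromethylphenyl pyrazole: a chain extension

The source may report more compounds than this note shows. Statements on the series, on what has been measured and on what is new or still open speak of the compounds shown alone.

Compound 1 `Cn1nc(-c2nnc(SCCOc3ccccc3F)o2)cc1-c1ccc(C(F)(F)F)cc1`, 23100 nM; compound 2 `Cn1nc(-c2ccc(C(F)(F)F)cc2)cc1-c1nnc(SCc2c(F)cccc2F)o1`, 46200 nM.

In a functional assay on MCF7 cells (Homo sapiens) for cytotoxicity, read by MTT assay, with a stated time of 24 h (a higher number here means a weaker inhibitor, a lower number a stronger inhibitor), compound 2 gives 46200 nM, the higher of the two numbers recorded, but its gap to compound 1 is within the scatter, so the two cannot be ordered. Compound 3 `Cn1nc(-c2ccc(C(F)(F)F)cc2)cc1-c1nnc(SCCc2ccc(F)cc2)o1` differs from compound 2 by 4-fluorobenzyl in place of 2,6-difluorophenyl on a saturated chain carbon bound to a sulfur. For the measured compounds named here, no measured pair shows what this kind of change does. Compound 3 is therefore expected to stay close to compound 2, with a step of a 1.3-fold lower number from compound 2 to compound 3 (0.12 log units; within the scatter) that is not expected to pass beyond the scatter in either direction. The estimate for compound 3 is 35000 nM, within 12000 nM to 100000 nM.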

Compound 3, half-maximal inhibitory concentration: 45400 nM
For compound 3 the middle estimate is 1.3-fold (0.11 log units) below the measured one; the measured number falls inside the stated range.
By their numbers in this assay, from the lowest: compounds 1, 3 and 2 (each within the scatter of the next).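

At this position, on a saturated chain carbon bound to a sulfur, 4-fluorobenzyl in place of 2,6-difluorophenyl gives in this assay a 1.0-fold lower number from compound 2 to compound 3 (0.01 log units; within the scatter). For the compounds shown here, this is the first measured pair for this change, and it shows that the change leaves the number within the scatter, so (2,6-difluorobenzyl)sulfanyl and (2-(4-fluorophenyl)ethyl)sulfanyl cannot be told apart here. No available evidence bears on this result. From the compounds shown here alone, whether an amine, a carboxylic acid or a longer chain at this place would move the number beyond the scatter remains open.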